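Dropping the Amino Group from Compound 2

The source may report more compounds than this note shows. Statements on the series, on what has been measured and on what is new or still open speak of the compounds shown alone.

Measured so far:
- compound 1, `Cc1cnc(N)nc1-c1ccccc1`, gives 34% in a functional assay on the whole organism for inhibition, with Rattus norvegicus as the target, with stated times of 1 h and 3.5 h, at a dose of 100 mg/kg by the oral route; a higher number here means more inhibition at the dose given (going by the name of the read-out), a lower number less inhibition.
- compound 2, `Nc1ncc2c(n1)CCCCCCCCCC2`, sits at the limit of this assay, < 5%.

Among the measured compounds shown here, compound 1 is the only one of the pair with a measured number. For compound 2 nothing more than a limit is known: it falls at the limit of < 5% in this assay, at which 1 of the 2 values shown sits, so the data say only that its inhibition lies under the reporting threshold, not where exactly.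

The unmeasured compound 3, `c1ncc2c(n1)CCCCCCCCCC2`, differs from compound 2 in one place: hydrogen in place of amino on an aromatic carbon. For the measured compounds named here, no step between two measured compounds exists here, so no measured size can be borrowed for this change. With compound 2 already at the limit, the expectation is that the step that the limit leaves unreadable from compound 2 to compound 3 will be none beyond the scatter, and that compound 3 will most likely also be reported only as a limit. Compound 3 is therefore estimated at 4%, with a range from 0% to 15%.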

Compound 3, a percentage reported as inhibition, in the whole organism at one dose (the size of the read-out at that dose, not a potency): < 5%
Compound 3: only a limit was reported (the forecaster's own chance of this, stated with the estimate: 70%); the middle value is on the limit's open side.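

Compound 2 and compound 3 are both reported only as limits, so no size can be read for the change from amino to hydrogen: the limit of < 5% in this assay, at which 2 of the 3 values shown sit.

The compounds shown leave open whether this change alters inhibition in this assay at all, and where the true values of compound 2 and compound 3 lie.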